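Benzyloxy halogen swap: chloro to bromo and clearance

The source may hold more compounds than are shown below. What is called first, only, known or untested is meant among the compounds shown, and "the series" means these compounds.

Compound 1 `O=C(O)c1cccc(C2=C(c3cc(Br)ccc3OCc3ccc(Cl)cc3)CCC2)c1` gives in an in vivo ADME assay on the whole organism (blood) for pharmacokinetics, with Rattus norvegicus as the target, at a dose of 1 mg/kg by the intravenous route (on this read-out lower numbers stand for slow clearance and higher numbers for fast clearance), a value of 33 mL/min/kg.
Compound 2 `O=C(O)c1cccc(C2=C(c3cc(Br)ccc3OCc3ccc(F)cc3F)CCC2)c1` gives in this assay a value of 35 mL/min/kg.
Compound 3 `O=C(O)c1cccc(C2=C(c3cc(Cl)ccc3OCc3ccccc3)CCC2)c1` gives in this assay a value of 54 mL/min/kg.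

Compound 3 carries a chloro group and an unsubstituted benzyloxy group; its number in this assay is the largest of the three, but its distance to compound 2 and to compound 1 lies within the scatter, so the three compounds cannot be told apart on these data. Within the data shown here, the only measured step, a 1.1-fold higher number from compound 1 to compound 2 (0.03 log units; within the scatter), changes the benzyl ring and leaves the value unmoved beyond the scatter. Compound 4 `O=C(O)c1cccc(C2=C(c3cc(Br)ccc3OCc3ccccc3)CCC2)c1` differs from compound 3 by bromo in place of chloro on an aromatic carbon. Among the measured compounds shown here, no measured pair shows this halogen swap alone; compound 1 and compound 2 carry bromo, compound 3 chloro, and all three sit within the scatter of one another. Compound 4 is therefore expected to show a step of a 1.1-fold lower number from compound 3 to compound 4 (0.05 log units; within the scatter) in this assay, no more than the scatter. The estimate for compound 4 is 48 mL/min/kg, within 28 mL/min/kg to 80 mL/min/kg.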

Compound 4, clearance: 52 mL/min/kg
Compound 4: middle estimate off by 1.1-fold (0.03 log units), on the low side; low and high end bracket the measured number.
By their numbers in this assay, from the lowest: compounds 1, 2, 4 and 3 (each within the scatter of the next).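

In this assay, the direct pair gives a 1.0-fold lower number from compound 3 to compound 4 (0.02 log units; within the scatter) for bromo in place of chloro on this aromatic carbon, para to a benzyloxy group, so this halogen swap alone does not separate the two compounds. With bromo held fixed, the unsubstituted benzyloxy group can now be read against its halogenated forms: a 1.5-fold higher number from compound 2 to compound 4 (0.17 log units; within the scatter) for phenyl in place of 2,4-difluorophenyl and a 1.6-fold higher number from compound 1 to compound 4 (0.20 log units; within the scatter) for hydrogen in place of chloro. Neither change therefore moves the number beyond the scatter in these compounds.

The compounds shown leave open whether a nitrile or a methoxy group on this aromatic carbon, or an amide in place of the carboxylic acid, would shift clearance beyond the scatter. No measurement at hand speaks to what sets the clearance of these compounds.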